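The source may hold more compounds than are shown below. What is called first, only, known or untested is meant among the compounds shown, and "the series" means these compounds.

Three related compounds have been tested in a functional assay on MCF7 cells (Homo sapiens) for antiproliferative activity, read by MTT assay, with a stated time of 72 h; on this read-out higher numbers stand for weaker inhibition and lower numbers for stronger inhibition. Compound 1 (`O=S1(=O)C=Cc2ccc(Nc3ccc(C(F)(F)F)cc3)cc21`) gives 1270 nM, compound 2 (`O=S1(=O)C=Cc2cccc(Nc3cccc(C(F)(F)F)c3)c21`) gives 750 nM, and compound 3 (`O=S1(=O)C=Cc2cccc(Nc3ccc(OC(F)(F)F)cc3)c21`) gives 2690 nM. Compound 3 therefore has the highest number of the three, which makes it the weakest inhibitor so far, and its gap to each of the other two lies beyond the usual scatter.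

Compound 4 (`Cc1ccc(Nc2cccc3c2S(=O)(=O)C=C3)cc1`) keeps the rest of compound 3 but carries methyl in place of trifluoromethoxy on an aromatic carbon. Among the compounds with values here, no measured pair shows this swap, so there is no direct guide to its effect. The measured values sit in a fairly narrow band, with compound 3 at its top at 2690 nM, so a modest move towards a lower number is expected rather than a large one. The expected change is a 1.8-fold lower number from compound 3 to compound 4 (0.25 log units; within the scatter), which would stay within the usual scatter. For compound 4 the estimated value is 1500 nM, with an expected range of 500 nM to 4500 nM.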

Compound 4, half-maximal inhibitory concentration: 1890 nM
The estimate for compound 4 lay 1.3-fold (0.10 log units) below the measured number, within the range that was stated.
By their numbers in this assay, from the lowest: compounds 2, 1, 4 and 3 (each within the scatter of the next, the first and the last beyond it).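

In this assay, methyl in place of trifluoromethoxy gives a 1.4-fold lower number from compound 3 to compound 4 (0.15 log units; within the scatter). Within the data shown here, this is the first look at this position, on an aromatic carbon para to a large group, and it shows that going from 5 heavy atoms, among them 3 fluorine and 1 oxygen, to the 1 carbon of methyl does not move the number beyond the scatter. Nothing available explains why so large a change in the group leaves the number so little changed.

Still open, on these data alone, is whether a group of another kind here, such as an amine, a carboxylic acid or a longer chain, would shift the number beyond the scatter. Compound 2 differs from compound 3 both in its group and in where that group sits, which leaves those two effects unseparated.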